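Ring methyl on the piperidine, taken after the chloro swap

A few compounds are considered here, and "the series" means these few. Any claim that something is new, unique, unknown or untested is made for them only; others in the source may bear on it.

Compound 1 `COc1cc2c(Nc3nc4ccc(C(=O)Nc5c(C)cccc5C)cc4s3)ncnc2cc1OCCCN1CCCCC1`, compound 2 `COc1cc2c(Nc3nc4ccc(C(=O)Nc5c(C)cccc5C)cc4s3)ncnc2cc1OCCCN1CCC(C)CC1` and compound 3 `COc1cc2c(Nc3nc4ccc(C(=O)Nc5c(C)cccc5Cl)cc4s3)ncnc2cc1OCCCN1CCCCC1` are measured; compound 4 `COc1cc2c(Nc3nc4ccc(C(=O)Nc5c(C)cccc5Cl)cc4s3)ncnc2cc1OCCCN1CCC(C)CC1` is not. In a functional assay on DLD-1 cells (Homo sapiens) for cytotoxicity, read by WST assay, with a stated time of 72 h (a higher number here means a weaker inhibitor, a lower number a stronger inhibitor), compound 1 gives > 100000 nM, which is a limit of the assay and not a number. Compound 2 in this assay gives > 100000 nM, again a limit and not a number. Going by the values given here, compound 3 in this assay gives 14700 nM, the only number in the set.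

The change from compound 1 to compound 2 is methyl in place of hydrogen on a saturated ring carbon. Its step, a step that the two limits leave unreadable from compound 1 to compound 2, stays unread because of the limit of > 100000 nM in this assay, at which 2 of the 3 values shown sit. The cores of compound 1 and compound 3 differ by chloro in place of methyl on an aromatic carbon, and this gives an at least 6.8-fold lower number from compound 1 to compound 3 (0.83 log units; beyond the scatter).

The change from compound 3 to compound 4 is methyl in place of hydrogen on a saturated ring carbon, the same change as from compound 1 to compound 2, at a place described in the same words. The earlier step carries no readable size, so the expectation rests on compound 3 alone, whose value 14700 nM is the starting point, with the added methyl treated as a change of small reach. The step is expected to be a 1.0-fold higher number from compound 3 to compound 4 (0.01 log units; within the scatter), inside the usual scatter. Compound 4 is estimated at 15000 nM, with a likely range from 5000 nM to 50000 nM.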

Compound 4, half-maximal inhibitory concentration: 11300 nM
Estimate against measurement, compound 4: 1.3-fold (0.12 log units) above; low and high end bracket the measured number.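

Working notes: in this assay, chloro in place of methyl on an aromatic carbon also lowers the number when the piperidin-1-yl group is replaced by 4-methylpiperidin-1-yl, with an at least 8.8-fold lower number from compound 2 to compound 4 (0.94 log units; beyond the scatter), so the direction of the change carries over between these two cores: the same change on two cores in this assay, an at least 6.8-fold lower number (0.83 log units; beyond the scatter) from compound 1 to compound 3 and an at least 8.8-fold lower number (0.94 log units; beyond the scatter) from compound 2 to compound 4; the limit leaves it open whether they differ. With chloro already in place, methyl in place of hydrogen on the saturated ring carbon gives a 1.3-fold lower number from compound 3 to compound 4 (0.11 log units; within the scatter), so compound 3 and compound 4 cannot be ordered in this assay. On these data alone, the true size of the chloro step on either core remains unknown, and the methyl step between compound 1 and compound 2 cannot be read, because compound 1 and compound 2 both stand at a limit of the assay and not at a number: the limit of > 100000 nM in this assay, at which 2 of the 4 values shown sit.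

The compounds shown leave open whether another group in place of chloro on that aromatic carbon, such as fluoro or trifluoromethyl, would give a step of similar size on both cores. They also leave open whether the methyl result would hold for a hydroxyl or dimethylamino group at the same ring carbon, or for a morpholin-4-yl group in place of the piperidin-1-yl group.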